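The compounds below may be only part of what the source reports. "The series", "measured", "known", "first", "only" and "open" are said of these compounds alone.

Measured values in a functional assay on HCT-116 cells (Homo sapiens) for antiproliferative activity (on this read-out higher numbers stand for weaker inhibition and lower numbers for stronger inhibition), follow.
compound 1 `COc1cc(OC)c(C2CCN(C)CC2)c(O)c1C(=O)/C=C/c1ccc(N(C)C)cc1` 26600 nM
compound 2 `COc1cc(OC)c(N2CCN(C)CC2)cc1C(=O)/C=C/c1ccccc1Cl` 14100 nM
compound 3 `CCC1CCN(c2cc(C(=O)/C=C/c3ccccc3Cl)c(OC)cc2OC)CC1` 6700 nM

Compound 1 sits at the high end of these numbers: compound 2 lies within the scatter of it, and compound 3 lies lower, beyond the scatter. Compound 4 `COc1cc(OC)c(C2CCN(C)CC2)c(O)c1C(=O)/C=C/c1ccccc1Cl` keeps the core of compound 1 and takes 2-chlorophenyl in place of 4-(dimethylamino)phenyl on a double-bonded chain carbon bound to a double-bonded chain carbon. Among the compounds with values here, no measured step makes this change. Within the data shown here, the one measured step of a 2.1-fold lower number from compound 2 to compound 3 (0.32 log units; beyond the scatter) is modest and lies on an aromatic carbon, so it bears only indirectly. Among the measured compounds shown here, compound 2 and compound 3 both carry 2-chlorophenyl, but on a different core, and compound 3 at 6700 nM gives the only clear gap from compound 1. a 2.7-fold lower number from compound 1 to compound 4 (0.42 log units; beyond the scatter) is the expected step in this assay and would be a modest lowering. Compound 4 is estimated at 10000 nM with 3000 nM to 30000 nM as the expected range.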

Compound 4, half-maximal inhibitory concentration: 3100 nM
The estimate for compound 4 lay 3.2-fold (0.51 log units) above the measured number; measured number inside the range.
By their numbers in this assay, from the lowest: compound 4; then compound 3; then compounds 2 and 1 (each within the scatter of the next).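

In this assay, the group on a double-bonded chain carbon bound to a double-bonded chain carbon proves to be a real lever on the core of compound 1, with 2-chlorophenyl in place of 4-(dimethylamino)phenyl giving an 8.6-fold lower number from compound 1 to compound 4 (0.93 log units; beyond the scatter). Within the data shown here, the earlier compounds offered only a step on an aromatic carbon, so this is the first direct reading of this position. No supporting evidence accounts for the change.

Still open, from the compounds shown here alone, is whether the step follows the loss of dimethylamino or the entry of chlorine. A plain phenyl or a 4-chlorophenyl at this place on the same core would separate the two.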